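The source may hold more compounds than are shown below. What is called first, only, known or untested is meant among the compounds shown, and "the series" means these compounds.

Of the compounds shown here, three built on one shared core have been tested in a functional assay on MGC-803 cells (Homo sapiens) for antiproliferative activity, read by CCK-8 assay, with a stated time of 72 h, tested at 2 uM; a higher number here means a stronger effect of the compound at the concentration tested, a lower number a weaker effect. Compound 1, `Nc1ccccc1NC(=O)c1ccc(CSC(=S)N2CCN(Cc3ccncc3)CC2)cc1`, carries a (pyridin-4-yl)methyl group on an amine nitrogen in a ring; in this assay compound 1 gives 18.4%. Compound 2, `CC1CCN(C(=S)SCc2ccc(C(=O)Nc3ccccc3N)cc2)CC1`, gives 28.1% in this assay, and compound 3, `Nc1ccccc1NC(=O)c1ccc(CSC(=S)N(Cc2ccccc2)Cc2ccccc2)cc1`, gives 11%. Among these three numbers compound 1 stands second highest; its nearest neighbour is compound 3, whose number sits lower by an amount within the usual scatter, and its furthest is compound 2, whose number sits higher, again within the scatter. None of the three can be called more or less active than another on these data.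

Compound 4, `Nc1ccccc1NC(=O)c1ccc(CSC(=S)N2CCN(C3CCCCC3)CC2)cc1`, is the next compound. Relative to compound 1 the change is cyclohexyl in place of (pyridin-4-yl)methyl on an amine nitrogen in a ring. Going by the values given here, no pair of measured compounds differs in exactly one place, so no measured step exists to calibrate this change. What can be said is that compound 2, which also carries a non-aromatic ring on its amine nitrogen, shows 28.1%, a number within the scatter of compound 1. The expected step is a number 3.6 percentage points higher from compound 1 to compound 4 (within the scatter), small and not beyond the scatter. Compound 4 is estimated to give 22% in this assay, with a range from 10% to 36%.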

Compound 4, a percentage reported as inhibition, at one concentration (the size of the read-out at that concentration, not a potency): 16.9%
Compound 4: middle estimate off by 5.1 percentage points, on the high side; measured number inside the range.
By their numbers in this assay, from the lowest: compounds 3, 4, 1 and 2 (each within the scatter of the next, the first and the last beyond it).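

Going by these compounds alone, replacing (pyridin-4-yl)methyl with cyclohexyl on an amine nitrogen in a ring is the first change in this set that can be read as a single step, and in this assay it gives a number 1.5 percentage points lower from compound 1 to compound 4 (within the scatter). An aromatic ring with a hetero atom and a hydrogen-bond acceptor leaves, and a non-aromatic ring of carbon only, with no hydrogen-bond acceptor, enters; at this position, in this pair, that exchange produces no difference that can be told from the usual scatter of repeated measurements. Nothing in the data shown explains this result or links it to any property of either group.

From the compounds shown here alone, both groups compared here are six-membered rings, so it remains open whether a different kind of group on this nitrogen, such as a longer chain ending in an amine or a carboxylic acid, would move the number beyond the scatter. Going by these compounds, this read-out also gives the size of the effect at one concentration rather than a potency, so any difference in potency between these two compounds remains unknown as well.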